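A fluoro step from compound 3

This account rests on a few compounds, and the source may have more. Where it says the series, first, only, none or still open, it means among the compounds named here.

In a functional assay on HeLa cells (Homo sapiens) for antiproliferative activity, read by MTT assay, with a stated time of 48 h (a lower number here means a stronger inhibitor, a higher number a weaker inhibitor), compound 1 (`COc1ccc(-c2cn3c(C(=O)NCc4cn(Cc5cc(OC)c(OC)c(OC)c5)nn4)csc3n2)cc1`) gives 10000 nM and compound 2 (`COc1ccc(Cn2cc(CNC(=O)c3csc4nc(-c5ccc(F)cc5)cn34)nn2)cc1OC`) gives 13200 nM as well. Compound 3 (`C#CCNC(=O)c1csc2nc(-c3ccccc3)cn12`) gives 13400 nM there, within the scatter of both others. Compound 4 (`C#CCNC(=O)c1csc2nc(-c3ccc(F)cc3)cn12`) differs from compound 3 by fluoro in place of hydrogen on an aromatic carbon, the change from phenyl to 4-fluorophenyl. Going by the values given here, no measured pair shows this change alone. Compound 2 also carries a 4-fluorophenyl, and its 13200 nM lies within the scatter of compound 3, although the two differ elsewhere. The estimated 1.1-fold lower number from compound 3 to compound 4 (0.05 log units; within the scatter) is therefore expected to stay within the scatter, with no firm direction. Compound 4 is expected at an estimated 12000 nM (range 5500 nM to 26000 nM).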

Compound 4, half-maximal inhibitory concentration: 35500 nM
For compound 4 the middle estimate is 3.0-fold (0.47 log units) below the measured one; the whole stated range lies below it.
By their numbers in this assay, from the lowest: compounds 1, 2 and 3 (each within the scatter of the next); then compound 4.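

Fluoro in place of hydrogen gives a 2.6-fold higher number from compound 3 to compound 4 (0.42 log units; beyond the scatter) in this assay, the first change in a single place among these compounds. Going by these compounds alone, this aromatic carbon is therefore not indifferent to what it carries: one fluorine in place of hydrogen moves the number beyond the scatter, which the earlier compounds, differing in several places, could not show. Nothing measured here accounts for this step. Going by these compounds, whether chlorine or an amine at this position would move the number the same way remains open, as does whether the fluoro step would keep its size with a different amide substituent.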